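The source may report more compounds than this note shows. Statements on the series, on what has been measured and on what is new or still open speak of the compounds shown alone.

In a functional assay (QGY7701 cells, Homo sapiens) for inhibition, read by MTT assay, with a stated time of 48 h (a higher number here means a weaker inhibitor, a lower number a stronger inhibitor), three compounds built on a shared core have been measured: compound 1 `COc1ccc2c(=O)c(/C=C/C(=O)Nc3ccccc3Cl)coc2c1` gives 23000 nM, compound 2 `COc1ccc2c(=O)c(/C=C/C(=O)NCc3ccc(F)cc3)coc2c1` gives 7960 nM and compound 3 `COc1ccc2c(=O)c(/C=C/C(=O)NCc3ccccc3F)coc2c1` gives 34000 nM. Compound 3 cannot be told apart from one of its neighbours, a 1.5-fold higher number from compound 1 to compound 3 (0.17 log units; within the scatter), but the gap to the other is real, a 4.3-fold higher number from compound 2 to compound 3 (0.63 log units; beyond the scatter).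

Compound 4 `COc1ccc2c(=O)c(/C=C/C(=O)NCc3ccc(C)cc3)coc2c1` differs from compound 3 by a single change, (4-methylphenyl in place of 2-fluorophenyl on a saturated chain carbon bound to an amide-type nitrogen), with 4-methylphenyl in place of 2-fluorophenyl on a saturated chain carbon bound to an amide-type nitrogen. For the measured compounds named here, no measured compound carries the methyl group, so the closest guide is compound 2, whose 4-fluorobenzyl group most resembles the incoming 4-methylbenzyl. That guide rests on a single pair of compounds, and compound 2 also stands apart from compound 1, a 2.9-fold lower number from compound 1 to compound 2 (0.46 log units; beyond the scatter). Going by the values given here, a modest step towards a lower number therefore seems likely, slightly smaller than the one seen with compound 2 at 7960 nM. The expected change is a 2.6-fold lower number from compound 3 to compound 4 (0.42 log units; beyond the scatter). The estimate for compound 4 is 13000 nM, with an expected range of 5000 nM to 32000 nM.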

Compound 4, half-maximal inhibitory concentration: 10200 nM
For compound 4 the middle estimate is 1.3-fold (0.11 log units) above the measured one; measured number inside the range.
By their numbers in this assay, from the lowest: compounds 2 and 4 (each within the scatter of the next); then compounds 1 and 3 (each within the scatter of the next).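

Replacing 2-fluorophenyl with 4-methylphenyl on the saturated chain carbon brings a 3.3-fold lower number from compound 3 to compound 4 (0.52 log units; beyond the scatter) and shows that a group with no fluorine at all can also stand clear of compound 3. Methyl in place of fluoro on the aromatic carbon gives a 1.3-fold higher number from compound 2 to compound 4 (0.11 log units; within the scatter) and so, in this cell assay, the 4-methylbenzyl and 4-fluorobenzyl groups cannot be told apart. The 4-methylbenzyl group also separates from the 2-chlorophenyl group on the amide-type nitrogen, with a 2.3-fold lower number from compound 1 to compound 4 (0.35 log units; beyond the scatter) and so compound 2 is no longer alone in doing this.

The compounds shown leave open what a methoxy group, a chlorine or a longer chain such as ethyl would do in place of the methyl group of compound 4. Why these numbers differ also stays open, as no supporting measurement bears on it.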